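Swapping the aryl amide: from fluorophenyl to trimethylpyrrole

The source may report more compounds than this note shows. Statements on the series, on what has been measured and on what is new or still open speak of the compounds shown alone.

For the measured compounds named here, compound 1 `O=C(Nc1ccc2nc(NC(=O)C3CCCCC3)sc2c1)c1ccccc1F` gives 0.14 ug/mL in a functional assay on WI-38 VA13 cells (Homo sapiens) for cytotoxicity (on this read-out higher numbers stand for an effect only at larger amounts of compound and lower numbers for an effect already at smaller amounts), the lower of the two numbers known; the only neighbour is compound 2 `Cc1nc(C)c(C(=O)Nc2ccc3nc(NC(=O)C4CCCCC4)sc3c2)s1`, which gives 0.39 ug/mL, a step of a 2.8-fold higher number from compound 1 to compound 2 (0.44 log units; beyond the scatter). Compound 3 `Cc1cc(C(=O)Nc2ccc3nc(NC(=O)C4CCCCC4)sc3c2)c(C)n1C` differs from compound 1 in one place: 1,2,5-trimethyl-1H-pyrrol-3-yl in place of 2-fluorophenyl on a carbonyl carbon. Going by the values given here, that earlier step, also a five-membered heteroaryl in place of 2-fluorophenyl on the carbonyl carbon, is the only guide, so a modest rise of similar size is expected, a 2.9-fold higher number from compound 1 to compound 3 (0.46 log units; beyond the scatter). Compound 3 is therefore estimated at 0.4 ug/mL, between 0.15 ug/mL and 1.1 ug/mL.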

Compound 3, half-maximal effective concentration: > 6.2 ug/mL
Compound 3 was reported as a limit; the forecaster's own chance of this, stated with the estimate: 3%; at least 15-fold (1.19 log units) between middle value and limit.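

In this assay, the reading for compound 3 is a limit and not a number: the limit of > 6.2 ug/mL in this assay, at which 1 of the 3 values shown sits. At this carbonyl carbon, 1,2,5-trimethyl-1H-pyrrol-3-yl gives an at least 44-fold higher number from compound 1 to compound 3 (1.64 log units; beyond the scatter), a large step. The two five-membered rings also differ sharply, with an at least 15-fold higher number from compound 2 to compound 3 (1.20 log units; beyond the scatter), so the outcome here depends on which five-membered ring enters, not only on 2-fluorophenyl leaving.

The compounds shown do not separate the contribution of the pyrrole ring from that of its three methyl groups. From the compounds shown here alone, an unsubstituted pyrrol-3-yl or a pyrrole with only the ring-nitrogen methyl would address this, and how far the number rises beyond the limit remains unknown.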